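A few compounds are considered here, and "the series" means these few. Any claim that something is new, unique, unknown or untested is made for them only; others in the source may bear on it.

Measured so far:
Compound 1, `Cc1ccccc1Nc1nnc(Nc2nc(-c3ccc(Br)cc3)cs2)s1`: in a functional assay on the whole organism (strain albino) with Mus musculus as the target, in the maximal electroshock model, with a stated time of 4 h (a lower number here means that less compound is needed, a higher number that more compound is needed for the effect), compound 1 gives 300 mg/kg.
Compound 2, `Cc1ccc(Nc2nnc(Nc3nc(-c4ccc(Br)cc4)cs3)s2)cc1`: in this assay compound 2 gives 100 mg/kg.

Among the measured compounds shown here, compound 2 stands at the lowest of the two numbers, so it needs the least compound for the effect; its only neighbour is compound 1, and the single step that has been measured is a 3.0-fold lower number from compound 1 to compound 2 (0.48 log units; beyond the scatter), which swaps 4-methylphenyl in place of 2-methylphenyl on a nitrogen on an aromatic ring.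

Compound 3, `COc1ccc(Nc2nnc(Nc3nc(-c4ccc(Br)cc4)cs3)s2)cc1`, keeps the core of compound 2 and changes one group: methoxy in place of methyl on an aromatic carbon. For the measured compounds named here, no measured step concerns this kind of exchange; the one known step only moves a methyl group and says nothing about a methoxy group. With nothing to point either way, the step from compound 2 to compound 3 is expected to stay within the scatter, no change at the digits printed from compound 2 to compound 3 (within the scatter). Compound 3 is therefore estimated at 100 mg/kg, with a range from 50 mg/kg to 300 mg/kg.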

Compound 3, minimum effective dose: 100 mg/kg
Compound 3: middle estimate and measured number agree at the digits printed; the range from low to high includes it.
By their numbers in this assay, from the lowest: compounds 2 and 3 (each within the scatter of the next); then compound 1.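

At the ring carbon para to a large group, methoxy in place of methyl gives no change at the digits printed from compound 2 to compound 3 (within the scatter) in this assay, so this position accepts one extra heavy atom, an oxygen counted as a hydrogen-bond acceptor, without a change in dose. Compound 1 had shown only that moving a methyl group matters, and the new comparison gives a 3.0-fold lower number from compound 1 to compound 3 (0.48 log units; beyond the scatter), close to what compound 2 showed. Among these three compounds, the 4-methylphenyl and 4-methoxyphenyl groups therefore sit together, and the 2-methylphenyl group of compound 1 stands apart from both.

As far as these compounds go, it remains open whether an amine, a carboxylic acid or a longer chain such as ethoxy would fit this same place equally well. Nothing at hand gives a reason for the flat step from methyl to methoxy.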